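Hexadecanamide series: fluoro for chloro on compound 3

The compounds below may be only part of what the source reports. "The series", "measured", "known", "first", "only" and "open" are said of these compounds alone.

Measured so far, all in an assay on HEK293 cells for inhibition of N-acylethanolamine-hydrolyzing acid amidase (Homo sapiens), read by scintillation counting, tested at 50 uM; a lower number here means less inhibition, a higher number more inhibition at the concentration tested (going by the name of the read-out):
- compound 1 `CCCCCCCCCCCCCCCC(=O)Nc1ccc([N+](=O)[O-])cc1` gives 15% in this assay.
- compound 2 `CCCCCCCCCCCCCCCC(=O)Nc1ccc(OC)cc1` is reported in this assay as "not active" (no number reported), with no number.
- compound 3 `CCCCCCCCCCCCCCCC(=O)NN1CCN(c2ccc(Cl)cc2)CC1` is reported in this assay as "not active" (no number reported), again with no number.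

Compound 3 therefore stands with no single value in this assay; it shares this with compound 2, so two of the three measured compounds carry no number and only compound 1 shows a low percentage of inhibition. Within the data shown here, no step between two measured compounds is available, and none of the three differ in one place from each other, so nothing in the measured set tells how this assay responds to a single change on the aryl group.

Compound 4 `CCCCCCCCCCCCCCCC(=O)NN1CCN(c2ccc(F)cc2)CC1` is the next entry, to be measured in this assay. It differs from compound 3 by fluoro in place of chloro on an aromatic carbon.

Given that compound 3 shows no measurable inhibition in this assay, no step beyond the usual scatter is expected in either direction; the expectation is that compound 4 also sits at the low end, quite possibly again without a reported number. Compound 4 is estimated at 5% in this assay, with the range 0% to 20%.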

Compound 4, a percentage reported as inhibition, at one concentration (the size of the read-out at that concentration, not a potency): "not active" (no number reported)
Compound 4 has no reported number here; there is nothing to compare the estimate with.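

Compound 3 and compound 4 are both reported in this assay as not active, without a number, so no step can be read for chloro to fluoro. No supporting data bear on this result. The compounds shown leave open whether any change at this aromatic carbon gives measurable inhibition in this assay at all.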